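Methoxy to trifluoromethoxy, starting from a limit

A few compounds are considered here, and "the series" means these few. Any claim that something is new, unique, unknown or untested is made for them only; others in the source may bear on it.

Of the compounds shown here, two sharing one core have been read so far, compound 1 (`CC(=O)Oc1ccc(/C=C/c2ccc3ccccc3c2)cc1`) and compound 2 (`COc1ccc(/C=C/c2ccc3ccccc3c2)cc1`). In a functional assay on P388 cells (Mus musculus) for inhibition (a higher number here means a weaker inhibitor, a lower number a stronger inhibitor), compound 1 gives > 5000 nM, which is a limit and not a number. In this assay compound 2 gives > 5000 nM, which is also a limit. Compound 2 therefore has no readable position in the series, and the evidence amounts to the limit of > 5000 nM in this assay, at which 2 of the 2 values shown sit.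

Compound 3 (`FC(F)(F)Oc1ccc(/C=C/c2ccc3ccccc3c2)cc1`) carries trifluoromethyl in place of methyl on an oxygen on an aromatic ring. Among the compounds with values here, the one measured step at this oxygen is a step that the two limits leave unreadable from compound 1 to compound 2, so it offers no size or direction to carry over. The expectation rests instead on compound 2 and its value of > 5000 nM, with no sign yet of measurable inhibition in this series. The expected change is a step that the limit leaves unreadable from compound 2 to compound 3, and no direction is supported. Compound 3 is estimated at 8000 nM, with an expected range of 3000 nM to 20000 nM, and will most likely be reported only as a limit.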

Compound 3, half-maximal inhibitory concentration: > 5000 nM
Compound 3 was reported as a limit; the forecaster's own chance of this, stated with the estimate: 80%; the middle value lies beyond the limit too.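

In this assay compound 3 gives > 5000 nM, which is a limit and not a number. The steps linking compound 3 to compound 1 and compound 2 therefore cannot be read. Left open is how strongly any of the three compounds inhibits, and whether the group on this oxygen changes that at all: the limit of > 5000 nM in this assay, at which 3 of the 3 values shown sit.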